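Replacing an Amino Group with Ethoxy: Expected Lipophilicity

A few compounds are considered here, and "the series" means these few. Any claim that something is new, unique, unknown or untested is made for them only; others in the source may bear on it.

Three measured compounds share one core. In a physicochemical assay for lipophilicity, read by HPLC, at pH 7.4 (a higher number here means a more lipophilic compound, a lower number a more polar compound), compound 1 `CNc1ncc(-c2ccc(S(C)(=O)=O)cc2)cc1-c1ccc(OC)nc1` gives 2.6. Compound 2 `COc1ccc(-c2cc(-c3ccc(S(C)(=O)=O)cc3)cnc2N)cn1` gives 2.2, and compound 3 `COc1ccc(-c2nc(-c3ccc(S(C)(=O)=O)cc3)cnc2N)cn1` gives 2.3. Compound 2 has the lowest number of the three, though compound 3 sits within the usual scatter of it, while compound 1 sits beyond. Among the measured compounds shown here, the only measured step is a number 0.40 log units lower from compound 1 to compound 2 (beyond the scatter). Compound 4 `CCOc1ncc(-c2ccc(S(C)(=O)=O)cc2)cc1-c1ccc(OC)nc1` differs from compound 2 in this way: ethoxy in place of amino on an aromatic carbon. Since taking one carbon off that nitrogen gave the step of a number 0.40 log units lower from compound 1 to compound 2 (beyond the scatter), adding two carbons and removing the hydrogen-bond donor in compound 4 is expected to give a larger step the other way, a number 1.10 log units higher from compound 2 to compound 4 (beyond the scatter). Compound 4 is therefore estimated at 3.3, ranging from 2.8 to 3.8.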

Compound 4, distribution coefficient: 3.7
For compound 4 the middle estimate is 0.40 log units below the measured one, within the range that was stated.
By their numbers in this assay, from the lowest: compounds 2, 3 and 1 (each within the scatter of the next, the first and the last beyond it); then compound 4.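

Ethoxy in place of amino on this aromatic carbon gives a number 1.50 log units higher from compound 2 to compound 4 (beyond the scatter) in this assay, and ethoxy in place of methylamino gives a number 1.10 log units higher from compound 1 to compound 4 (beyond the scatter) as well. The earlier compounds shown here showed only a modest step between two nitrogen-linked groups at this position, whereas an oxygen-linked chain moves the number much further from either of them. No available evidence accounts for the size of these steps.

From the compounds shown here alone, whether methoxy or the longer propoxy would fall short of ethoxy or pass it remains open. So does where dimethylamino would stand at this position.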